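This account rests on a few compounds, and the source may have more. Where it says the series, first, only, none or still open, it means among the compounds named here.

Compound 1 `O=c1cc(Cn2cc(CCO)nn2)c2ccc(O)cc2o1` is the starting point. In a functional assay on HeLa cells (Homo sapiens) for inhibition, read by MTT assay, with a stated time of 72 h (on this read-out higher numbers stand for weaker inhibition and lower numbers for stronger inhibition), compound 1 reaches only the limit of the measurement, > 100000 nM, so no exact number is known for it. Two measured neighbours show what happens when the 2-hydroxyethyl group on the shared core is exchanged. Compound 2 `O=c1cc(Cn2cc(-c3cc(F)cc(F)c3)nn2)c2ccc(O)cc2o1` carries a 3,5-difluorophenyl there and gives 27600 nM in this assay; compound 3 `O=c1cc(Cn2cc(-c3ccc(Br)cc3)nn2)c2ccc(O)cc2o1` carries a 4-bromophenyl and gives 40200 nM. These exchanges gave an at least 3.6-fold lower number from compound 1 to compound 2 (0.55 log units; beyond the scatter) and an at least 2.4-fold lower number from compound 1 to compound 3 (0.39 log units; beyond the scatter), while between compound 2 and compound 3 the difference is a 1.5-fold higher number from compound 2 to compound 3 (0.16 log units; within the scatter).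

Compound 4 `O=c1cc(Cn2cc(CSC(=S)N3CCOCC3)nn2)c2ccc(O)cc2o1` is not yet measured. It differs from compound 1 by a group of 9 heavy atoms (5 carbon, 1 nitrogen, 1 oxygen, 2 sulfur; one six-membered non-aromatic ring with 2 hetero atoms) in place of a group of 2 heavy atoms (1 carbon, 1 oxygen; no ring), on a saturated chain carbon bound to an aromatic carbon. Both measured exchanges at the same side chain lowered the number by at least a modest amount, and a similar, modest lowering is expected here, although the entering group is quite unlike the two aromatic rings. The step from compound 1 to compound 4 in this assay is estimated as an at least 2.8-fold lower number from compound 1 to compound 4 (0.45 log units; beyond the scatter). For compound 4 the expected value is 35000 nM, most likely between 10000 nM and 100000 nM.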

Compound 4, half-maximal inhibitory concentration: 40800 nM
The estimate for compound 4 lay 1.2-fold (0.07 log units) below the measured number; the measured number falls inside the stated range.
By their numbers in this assay, from the lowest: compounds 2, 3 and 4 (each within the scatter of the next). At a limit, above all of these: compound 1.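

In this assay the new exchange gives an at least 2.4-fold lower number from compound 1 to compound 4 (0.38 log units; beyond the scatter), so the lowering at this side chain is not confined to entering aromatic rings: the group entering here holds a six-membered non-aromatic ring with 2 hetero atoms and has 0 hydrogen-bond donors. Compounds 2, 3 and 4 lie each within the scatter of the next, so this assay does not separate these very different groups from one another. The full size of the step stays unknown because compound 1 sits at a limit of the assay: the limit of > 100000 nM in this assay, at which 1 of the 4 values shown sits.

The compounds shown leave open which part of the entering group carries the change, the morpholine ring or the sulfur-containing link. They also leave open how a simple amine, a carboxylic acid or a longer alkyl chain would behave at this place.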